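The source may hold more compounds than are shown below. What is called first, only, known or untested is meant among the compounds shown, and "the series" means these compounds.

Measured so far:
compound 1 `ClCc1cccc(Cn2cnc3ncnc(Cl)c32)c1` — > 100000 nM
compound 2 `ClCc1ccccc1Cn1cnc2ncnc(Cl)c21` — > 100000 nM

In a functional assay on NCI-H522 cells (Homo sapiens) for cytotoxicity, read by sulforhodamine B assay, with a stated time of 48 h (a lower number here means that less compound is tolerated, a higher number that more compound is tolerated), compound 1 reaches only the assay limit, > 100000 nM. Compound 2 likewise gives only a limit, > 100000 nM. Among the measured compounds shown here, compound 2 therefore stands at the ceiling of the measured range, together with the one other value shown (the limit of > 100000 nM in this assay, at which 2 of the 2 values shown sit). Compound 3 `ClCc1ccccc1Cn1cnc2nc(Cl)nc(Cl)c21` differs from compound 2 by chloro in place of hydrogen on an aromatic carbon. For the measured compounds named here, no measured step covers this change; the expected shift a number no higher from compound 2 to compound 3 (the limit leaves the size open) is none beyond the scatter. Compound 3 is accordingly expected at 100000 nM, range 30000 nM to 300000 nM, most probably again reported only as a limit.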

Compound 3, concentration lethal to 50% of the cells: > 100000 nM
Compound 3 ended at the assay's limit; the forecaster's own chance of this, stated with the estimate: 75%; the middle value sits exactly at the limit.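

No step can be read between compound 2 and compound 3, because both stand at the same limit: the limit of > 100000 nM in this assay, at which 3 of the 3 values shown sit.

The compounds shown leave open whether compound 1, compound 2 and compound 3 differ at all, and what the added chloro changes.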